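The source may hold more compounds than are shown below. What is called first, only, known or untested is meant among the compounds shown, and "the series" means these compounds.

Measured in a functional assay on RL cells (Homo sapiens) for antiproliferative activity, read by MTT assay, with a stated time of 72 h; a higher number here means a weaker inhibitor, a lower number a stronger inhibitor:

- compound 1 `COc1cc(/C=C\c2cc3cc(F)ccc3s2)cc(OC)c1OC`: 38 nM
- compound 2 `COc1cc(/C=C\c2cc3cc(O)ccc3s2)cc(OC)c1OC`: "not determined" (no result reported)
- compound 3 `COc1cc(/C=C\c2sc3ccccc3c2C)cc(OC)c1OC`: 61 nM

Of the two numbers available, compound 3 stands at 61 nM, within the scatter of compound 1 at 38 nM, while compound 2 has no number. The unmeasured compound 4 `COc1cc(/C=C\c2cc3ccccc3s2)cc(OC)c1OC` departs from compound 3 with hydrogen in place of methyl on an aromatic carbon. Going by the values given here, no measured pair shows this change alone, so the expectation rests only on how close compound 1 at 38 nM and compound 3 at 61 nM lie. In this assay, no step beyond the scatter is expected, in either direction. The expected step is a 1.5-fold lower number from compound 3 to compound 4 (0.18 log units; within the scatter). For compound 4 the estimate is 40 nM, with an expected range of 15 nM to 110 nM.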

Compound 4, half-maximal inhibitory concentration: 7.6 nM
Compound 4: middle estimate off by 5.3-fold (0.72 log units), on the high side; the measured number lies below the stated range.
By their numbers in this assay, from the lowest: compound 4; then compounds 1 and 3 (each within the scatter of the next).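

In this assay, going by these compounds alone, hydrogen in place of methyl on the aromatic carbon of the five-membered ring gives an 8.0-fold lower number from compound 3 to compound 4 (0.90 log units; beyond the scatter), so this position responds to a change of a single carbon, which the earlier compounds could not show. Hydrogen in place of fluoro on an aromatic carbon gives a 5.0-fold lower number from compound 1 to compound 4 (0.70 log units; beyond the scatter), so in both pairs the compound carrying hydrogen has the lower number. Nothing given here explains either step. On these data alone, how an ethyl, a methoxy or an amine on this carbon would compare with methyl and hydrogen remains open.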